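This account rests on a few compounds, and the source may have more. Where it says the series, first, only, none or still open, it means among the compounds named here.

Compound 1 `ClCc1cccc(Cn2cnc3ncnc(Cl)c32)c1` and compound 2 `ClCc1cccc(Cn2cnc3c(Cl)nc(Cl)nc32)c1` share a core. In a functional assay on U-251 cells (Homo sapiens) for cytotoxicity, read by sulforhodamine B assay, with a stated time of 48 h (on this read-out higher numbers stand for weaker inhibition of growth and lower numbers for stronger inhibition of growth), compound 1 gives 1940 nM, while compound 2 gives 1690 nM; compound 1 thus holds the higher of the two numbers, but the gap falls within the usual scatter, so the two cannot be told apart. Compound 3 `ClCc1cccc(Cn2cnc3nc(Cl)nc(Cl)c32)c1` differs from compound 1 by chloro in place of hydrogen on an aromatic carbon. Within the data shown here, no measured pair shows this exact change, so the only guide is compound 2, which also carries an added chloro on the core and sits within the scatter of compound 1. Compound 3 is therefore expected to give about 1500 nM in this assay, from 700 nM to 3500 nM. The step of a 1.3-fold lower number from compound 1 to compound 3 (0.11 log units; within the scatter) is expected to be small, no larger than the scatter, with no clear direction.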

Compound 3, concentration for 50% growth inhibition: 1380 nM
Compound 3: the middle estimate sits 1.1-fold (0.04 log units) above what was measured, within the range that was stated.
By their numbers in this assay, from the lowest: compounds 3, 2 and 1 (each within the scatter of the next).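

In this assay, chloro in place of hydrogen on the aromatic carbon between two ring nitrogen atoms gives a 1.4-fold lower number from compound 1 to compound 3 (0.15 log units; within the scatter). Among these compounds, this is the first direct reading of the change at this position, and it shows that the position carries a chloro without a step that can be told from the scatter. No measurement at hand bears on this result.
From the compounds shown here alone, whether an amine or a methoxy group on this same carbon would also stay within the scatter of compound 1 remains open.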